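Methyl Additions on a Shared Bicyclic Core

A few compounds are considered here, and "the series" means these few. Any claim that something is new, unique, unknown or untested is made for them only; others in the source may bear on it.

Of the compounds shown here, three built on the same core have been tested in a functional assay on 786-0 cells (Homo sapiens); a higher number here means a weaker inhibitor of growth, a lower number a stronger inhibitor of growth. Compound 1, `Cc1cc(C)c2c(O)cc(-c3ccc(Cl)cc3)nc2n1`, gives 21400 nM. Compound 2, `Cc1ccnc2nc(-c3ccc(Cl)cc3)cc(O)c12`, gives 3980 nM. Compound 3, `COc1ccccc1-c1cc(O)c2cccnc2n1`, gives 36300 nM, the highest of the three numbers, though its gap to compound 1 lies within the scatter, while its gap to compound 2 lies beyond it.

Among the measured compounds shown here, the single counted step among the measured compounds is methyl in place of hydrogen on an aromatic carbon, which produced a 5.4-fold higher number from compound 2 to compound 1 (0.73 log units; beyond the scatter). The difference between the cores of compound 2 and compound 3 is not broken down here.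

Compound 4, `COc1ccccc1-c1cc(O)c2c(C)ccnc2n1`, is not yet measured. It arises from compound 3 through (methyl in place of hydrogen on an aromatic carbon). This is the same kind of change as that from compound 2 to compound 1, but not the same: there the methyl entered next to the ring nitrogen, meta to a methyl group and para to a fused ring, whereas here it enters ortho to a fused ring and opposite the ring nitrogen. Because the earlier step gave a 5.4-fold higher number from compound 2 to compound 1 (0.73 log units; beyond the scatter) at a different place, and compound 2 carries a methyl at the place now filled yet gives 3980 nM, the expected step is a 1.5-fold lower number from compound 3 to compound 4 (0.16 log units; within the scatter), roughly flat. Compound 4 is accordingly estimated at 25000 nM, between 8000 nM and 70000 nM, in this assay.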

Compound 4, concentration for 50% growth inhibition: 60300 nM
The estimate for compound 4 lay 2.4-fold (0.38 log units) below the measured number; low and high end bracket the measured number.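

In this assay, methyl in place of hydrogen on an aromatic carbon gave a 1.7-fold higher number from compound 3 to compound 4 (0.22 log units; within the scatter), so the sizeable step seen earlier did not recur on the core of compound 3. The same change therefore cannot be carried from one core to the other in this series with its size intact, as the two steps differ: the same change on two cores in this assay, a 5.4-fold higher number (0.73 log units; beyond the scatter) from compound 2 to compound 1 and a 1.7-fold higher number (0.22 log units; within the scatter) from compound 3 to compound 4, 3.2-fold (0.51 log units) apart, beyond the scatter of two such steps. Among the compounds shown here, this does not show that the core alone sets the size of the step, since the two steps also differ in where the methyl enters: in compound 4 it stands ortho to a fused ring and opposite the ring nitrogen, a place that compound 2 already fills with methyl, and with only two steps, the place and the rest of the core cannot be told apart.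

The compounds shown leave open how a group other than methyl, such as an amine, a carboxylic acid or a longer chain, would fare at the place opposite the ring nitrogen. They also leave open whether a methyl entering at one and the same place on both cores would give matching steps.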